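A few compounds are considered here, and "the series" means these few. Any claim that something is new, unique, unknown or untested is made for them only; others in the source may bear on it.

Working notes on the series, all read in a functional assay on MCF7 cells (Homo sapiens) for inhibition; a higher number here means a weaker inhibitor of growth, a lower number a stronger inhibitor of growth. Compound 1 `CCOC(=O)c1ccsc1NC(=O)[C@@H]1CCCN1` gives only a limit, > 250 ug/mL. Among the compounds with values here, compound 2 `O=C(OC1CCCCC1)c1ccsc1NC(=O)[C@@H]1CCCN1` gives 162 ug/mL, the only actual number so far in this assay. Cyclohexyl in place of ethyl on an oxygen next to a carbonyl group accounts for an at least 1.5-fold lower number from compound 1 to compound 2 (0.18 log units; that floor lies within the scatter). On these data alone, that figure is a floor, and the true size of the step stays open because of the limit of > 250 ug/mL in this assay, at which 1 of the 2 values shown sits.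

Compound 3 `O=C(OCC(Cl)(Cl)Cl)c1ccsc1NC(=O)[C@@H]1CCCN1` carries 2,2,2-trichloroethyl in place of cyclohexyl on an oxygen next to a carbonyl group. Within the data shown here, the one measured step at this place, an at least 1.5-fold lower number from compound 1 to compound 2 (0.18 log units; that floor lies within the scatter), is the only guide, and it does not test the entering group. It gives no firm ground for expecting a shift beyond the scatter, though the ring-free ethyl of compound 1, at > 250 ug/mL, allows a slight lean towards a higher number. The estimated step is a 1.1-fold higher number from compound 2 to compound 3 (0.05 log units; within the scatter), so no real change is expected. The expected value for compound 3 is 180 ug/mL, with an estimated range of 90 ug/mL to 250 ug/mL.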

Compound 3, concentration for 50% growth inhibition: > 250 ug/mL
Compound 3: only a limit was reported; the forecaster's own chance of this, stated with the estimate: 30%; middle value at least 1.3-fold (0.14 log units) away from the limit.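

In this assay, within the data shown here, 2,2,2-trichloroethyl in place of cyclohexyl on an oxygen next to a carbonyl group gives an at least 1.5-fold higher number from compound 2 to compound 3 (0.18 log units; that floor lies within the scatter), the first reading of a second group leaving from cyclohexyl at this place, though that floor alone does not establish a real change. Compound 3 gives only a limit, > 250 ug/mL. Cyclohexyl in compound 2 therefore remains the only group at this place with an actual number, and neither ring-free group, the ethyl of compound 1 or the 2,2,2-trichloroethyl of compound 3, gives one, so the step between those two compounds cannot be read: the limit of > 250 ug/mL in this assay, at which 2 of the 3 values shown sit.

Still open, on these data alone, is whether the actual number in compound 2 goes with the ring of cyclohexyl or with the carbon count of the group, a question that a cyclopentyl ester, a phenyl ester or an n-hexyl ester would help to separate. As far as these compounds go, the true distance of compound 1 and compound 3 from compound 2 also stays open, and so does whether any group at this place can move the number clearly beyond the scatter.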